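Carboxylated pyridyl ring as the terminal group of compound 4

The source may hold more compounds than are shown below. What is called first, only, known or untested is meant among the compounds shown, and "the series" means these compounds.

Compound 1 `CCC(C)(C)Cc1c[nH]c(CCc2ccc(-c3ccccc3C(=O)O)cc2)n1` is one of three agonists sharing a core, the others being compound 2 `c1ccc(-c2ccc(CCc3nc(CC4CCCC4)c[nH]3)cc2)nc1` and compound 3 `CCC(C)(C)Cc1c[nH]c(CCc2ccc(-c3cccnc3)cc2)n1`. In a functional assay on HEK293 cells for agonist activity at Bombesin receptor subtype-3 (Mus musculus), read by luminescence and calcium flux, with a stated time of 10 min (a lower number here means that less compound is needed, a higher number that more compound is needed for the effect), compound 1 gives 94 nM, compound 3 gives 97 nM, and compound 2 gives 103 nM; compound 1 carries the lowest of the three numbers, but its gaps to both companions lie within the scatter, so the three are not separated. The change under study is 2-carboxypyridin-3-yl in place of 2-carboxyphenyl on an aromatic carbon, leading to compound 4 `CCC(C)(C)Cc1c[nH]c(CCc2ccc(-c3cccnc3C(=O)O)cc2)n1`. Going by the values given here, the only measured step that bears on it is the exchange of the same terminal aryl group, where a 1.0-fold higher number from compound 1 to compound 3 (0.01 log units; within the scatter); that change, larger in kind than the present one, moved the number not at all beyond the scatter. Compound 4 is therefore expected to sit close to compound 1 in this assay, with a 1.1-fold higher number from compound 1 to compound 4 (0.03 log units; within the scatter) and no step beyond the scatter. The estimate for compound 4 is 100 nM, within a range from 45 nM to 220 nM.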

Compound 4, half-maximal effective concentration: 97 nM
Beside the measured number, compound 4's estimate is 1.0-fold (0.01 log units) above it; the range from low to high includes it.
By their numbers in this assay, from the lowest: compounds 1, 3, 4 and 2 (each within the scatter of the next).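

In this assay, 2-carboxypyridin-3-yl in place of 2-carboxyphenyl, on an aromatic carbon para to a large group, gives a 1.0-fold higher number from compound 1 to compound 4 (0.01 log units; within the scatter), so a ring nitrogen entering the carboxylated ring leaves the number within the scatter. The earlier step had exchanged the ring and removed the carboxy group at once, whereas carboxy in place of hydrogen on the pyridine ring now stands alone and gives no change at the digits printed from compound 3 to compound 4 (within the scatter). The three terminal groups are thus not separated at this position, whether or not the carboxy group is present, and nothing available accounts for this.

The compounds shown leave open whether a methyl ester, a primary amide or an amine in place of the carboxy group would move the number. They also leave open whether a saturated ring such as cyclohexyl would do so in place of the terminal aromatic ring.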